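The compounds below may be only part of what the source reports. "The series", "measured", "known", "first", "only" and "open" are said of these compounds alone.

Working notes on the series. In a functional assay on the whole organism (Central nervous system) with Mus musculus as the target (on this read-out higher numbers stand for an effect only at larger amounts of compound and lower numbers for an effect already at smaller amounts), compound 3 `COc1ccc(C(=O)CCC(=O)NCCCO)cc1` gives 800 mg/kg, the highest of the three numbers recorded so far. Compound 1 `O=C(CCC(=O)c1ccc(F)cc1)NCCCO` gives 500 mg/kg in this assay, and the step of a 1.6-fold higher number from compound 1 to compound 3 (0.20 log units; within the scatter) stays within the scatter. Compound 2 `Cc1ccc(C(=O)CCC(=O)NCCCO)c(C)c1` gives 150 mg/kg in this assay, which lies beyond the scatter of compound 3.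

The next step leads to compound 4 `Cc1ccc(C(=O)CCC(=O)NCCCO)cc1`: methyl in place of methoxy on an aromatic carbon. Going by the values given here, no measured step exchanges methoxy for methyl, so none of the recorded steps bears directly on this change; the one recorded step, from fluoro to methoxy, is within the scatter and gives no direction. Among the compounds with values here, compound 2 is the only measured compound carrying methyl on an aromatic carbon and stands at 150 mg/kg, but it differs from compound 4 in more than one place, so its value is only a loose pointer. A modest move toward lower numbers is expected, a 2.3-fold lower number from compound 3 to compound 4 (0.36 log units; beyond the scatter), near the edge of the scatter. Compound 4 is therefore estimated at 350 mg/kg, with a range from 120 mg/kg to 1000 mg/kg.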

Compound 4, dose for half-maximal effect: 700 mg/kg
Compound 4: middle estimate off by 2.0-fold (0.30 log units), on the low side, and the stated range covers the measured number.
By their numbers in this assay, from the lowest: compound 2; then compounds 1, 4 and 3 (each within the scatter of the next).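

In this assay the change from methoxy to methyl, para to a large group, gives a 1.1-fold lower number from compound 3 to compound 4 (0.06 log units; within the scatter) and the change from fluoro to methyl gives a 1.4-fold higher number from compound 1 to compound 4 (0.15 log units; within the scatter) so fluoro, methoxy and methyl are not told apart at this position. The one step beyond the scatter is a 4.7-fold higher number from compound 2 to compound 4 (0.67 log units; beyond the scatter) for hydrogen in place of methyl on an aromatic carbon, so among these compounds the difference goes with the extra methyl of compound 2 and not with the exchange of groups at this position. No measurement at hand offers an explanation for either finding.

As far as these compounds go, whether an amine or a carboxylic acid at this position would also leave the number within the scatter remains open. Also open, from the compounds shown here alone, is whether the extra methyl would give a similar step alongside fluoro or methoxy, and what a longer chain on the amide would do.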